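Swapping Phenyl for Thiophene on a Shared Core

A few compounds are considered here, and "the series" means these few. Any claim that something is new, unique, unknown or untested is made for them only; others in the source may bear on it.

Compound 1, `c1ccc(-c2cn3ccnc3c(-c3ccc4ncn(C5CCCCC5)c4c3)n2)cc1`, gives 70.6% in a functional assay on K562 cells (Homo sapiens) for inhibition, read by sulforhodamine B assay, with a stated time of 48 h, tested at 10 uM; a lower number here means less inhibition, a higher number more inhibition at the concentration tested (going by the name of the read-out).
Compound 2, `Brc1ccc(-c2cn3ccnc3c(-c3ccc4ncn(C5CCCCC5)c4c3)n2)cc1`, gives 59% in this assay.
Compound 3, `COc1ccccc1-c1cn2ccnc2c(-c2ccc3ncn(C4CCCCC4)c3c2)n1`, gives 22.6% in this assay.

Among these three numbers compound 1 stands highest. Putting bromo in place of hydrogen on an aromatic carbon of the pendant ring gave a number 11.6 percentage points lower from compound 1 to compound 2 (beyond the scatter), and putting methoxy in place of hydrogen gave a number 48 percentage points lower from compound 1 to compound 3 (beyond the scatter). Between the two substituted compounds, the change to 2-methoxyphenyl in place of 4-bromophenyl gave a number 36.4 percentage points lower from compound 2 to compound 3 (beyond the scatter). Every change made so far to the unsubstituted phenyl of compound 1 has lowered the inhibition.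

Compound 4, `c1csc(-c2cn3ccnc3c(-c3ccc4ncn(C5CCCCC5)c4c3)n2)c1`, differs from compound 1 in a different way: thiophen-2-yl in place of phenyl on an aromatic carbon. Among the measured compounds shown here, none of the measured steps replaces the whole ring, so they bear only loosely on this change. What they show is that compound 1 has not yet been beaten and that alterations to this ring have so far cost inhibition, once modestly and once by a large amount. A modest drop from compound 1 to compound 4 is therefore expected, a number 10.6 percentage points lower from compound 1 to compound 4 (beyond the scatter), though a result within the scatter would not surprise.

Compound 4 is thus estimated at 60% in this assay, with a likely range from 40% to 78%.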

Compound 4, a percentage reported as inhibition, at one concentration (the size of the read-out at that concentration, not a potency): 27%
For compound 4 the middle estimate is 33 percentage points above the measured one; measured number outside the range, below it.
By their numbers in this assay, from the lowest: compounds 3 and 4 (each within the scatter of the next); then compound 2; then compound 1.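

The earlier steps shown here only added a group to the phenyl ring, whereas this one replaces the ring itself, and that alone costs a great deal of inhibition in this assay: thiophen-2-yl in place of phenyl gives a number 43.6 percentage points lower from compound 1 to compound 4 (beyond the scatter). The thiophen-2-yl ring carries no added group, yet it also falls short of the 4-bromophenyl ring, with a number 32 percentage points lower from compound 2 to compound 4 (beyond the scatter), while its comparison with the 2-methoxyphenyl ring gives a number 4.4 percentage points higher from compound 3 to compound 4 (within the scatter), so those two rings cannot be told apart here. At this position, on the carbon next to the ring nitrogen of the shared core, the plain phenyl of compound 1 therefore remains the best of the four groups, and none of the three replacements matches it.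

Nothing measured here explains why the five-membered ring loses so much inhibition. As far as these compounds go, it remains open whether a pyridine ring in place of the phenyl would keep the inhibition of compound 1, and whether an amine or a carboxylic acid on the phenyl would lower it as bromo and methoxy do.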